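The source may report more compounds than this note shows. Statements on the series, on what has been measured and on what is new or still open speak of the compounds shown alone.

Measured in an ADME assay on Vero cells (Chlorocebus sabaeus) for cytotoxicity, read by MTT assay, with a stated time of 72 h; a lower number here means that less compound is tolerated, a higher number that more compound is tolerated:
Compound 1, `COC(=O)c1cc(-c2cccc(NC(=O)c3ccc(/C=C/C(=O)c4cc(F)ccc4F)cc3)c2)on1`, gives > 40 ug/mL, which is a limit of the assay rather than a number.
Compound 2, `COC(=O)c1cc(-c2cccc(NC(=O)c3ccc(/C=C/C(=O)c4cccc(C(F)(F)F)c4)cc3)c2)on1`, gives > 20 ug/mL, again only a limit.
Compound 3, `CCOc1ccc(C(=O)/C=C/c2ccc(C(=O)Nc3cccc(-c4cc(C(=O)OC)no4)c3)cc2)cc1`, gives > 40 ug/mL, again only a limit.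

Compound 1 therefore stands at a limit, and the two further values are limits as well, so none of the three compounds has a true number in this assay. The three steps among them, a step that the two limits leave unreadable from compound 1 to compound 2, a step that the two limits leave unreadable from compound 1 to compound 3 and a step that the two limits leave unreadable from compound 2 to compound 3, all exchange the ring on the carbonyl carbon, and each is unreadable in size, since both ends sit at limits. The change to compound 4, `COC(=O)c1cc(-c2cccc(NC(=O)c3ccc(/C=C/C(=O)c4ccc(C)c(F)c4)cc3)c2)on1`, is of the same kind: 3-fluoro-4-methylphenyl in place of 2,5-difluorophenyl on a carbonyl carbon.

The evidence that bears on this step is the limit of > 40 ug/mL in this assay, at which 2 of the 3 values shown sit, together with the limit of > 20 ug/mL in this assay, at which 1 of the 3 values shown sits. For the measured compounds named here, every exchange at this position so far has left the compound tolerated up to the highest concentration tested, so no step beyond the scatter is expected for compound 4 in this assay, and most likely only a limit will again be reported.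

Compound 4 is estimated at 45 ug/mL, with a range of 20 ug/mL to 100 ug/mL, which would mean an expected step that the limit leaves unreadable from compound 1 to compound 4.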

Compound 4, half-maximal cytotoxic concentration: > 50 ug/mL
Compound 4: only a limit was reported; the forecaster's own chance of this, stated with the estimate: 80%; at least 1.1-fold (0.04 log units) between middle value and limit.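

In this assay compound 4 gives > 50 ug/mL, which is only a limit. Compound 1, compound 2 and compound 3 also stand at limits, so the steps from each of them to compound 4 cannot be read. Still open, as far as these compounds go, is the concentration at which any of these four compounds harms the cells, and whether exchanging the ring on the carbonyl carbon changes it.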